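A few compounds are considered here, and "the series" means these few. Any claim that something is new, unique, unknown or untested is made for them only; others in the source may bear on it.

Measured so far: compound 1 `Cc1cc(C#N)cc(C)c1Oc1cc(Nc2ccc(C#N)cc2)c([N+](=O)[O-])cc1[N+](=O)[O-]`; compound 2 `Cc1cc(Br)cc(C)c1Oc1cc(Nc2ccc(C#N)cc2)c(N)cc1N`; compound 3 `Cc1cc(C#N)cc(C)c1Oc1cc(Nc2ccc(C#N)cc2)c(N)cc1[N+](=O)[O-]`.

In an ADME assay on H9 cells (Homo sapiens) for cytotoxicity, read by XTT assay, with a stated time of 6 days (a lower number here means that less compound is tolerated, a higher number that more compound is tolerated), compound 1 gives > 58200 nM, which is a limit of the assay and not a number. Compound 2 gives 38400 nM in this assay. Compound 3 gives 62700 nM in this assay. The step that the limit leaves unreadable from compound 1 to compound 3 cannot be sized because of the limit of > 58200 nM in this assay, at which 1 of the 3 values shown sits. Compound 4 `Cc1cccc(C)c1Oc1cc(Nc2ccc(C#N)cc2)c([N+](=O)[O-])cc1[N+](=O)[O-]` is not yet measured in this assay. It differs from compound 1 in one place: hydrogen in place of cyano on an aromatic carbon. For the measured compounds named here, no measured step covers this change, so no shift beyond the scatter is expected. The expected step is a step that the limit leaves unreadable from compound 1 to compound 4. Compound 4 is therefore estimated at 60000 nM in this assay, with a range from 30000 nM to 150000 nM.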

Compound 4, half-maximal cytotoxic concentration: > 61800 nM
Compound 4 ended at the assay's limit; the forecaster's own chance of this, stated with the estimate: 60%; middle value at least 1.0-fold (0.01 log units) from the limit.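

In this assay, no step can be read from compound 1 to compound 4, because both values are limits of the assay and not numbers: the limit of > 61800 nM in this assay, at which 1 of the 4 values shown sits.

The compounds shown leave open whether hydrogen in place of cyano changes the tolerated concentration at all.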